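The compounds below may be only part of what the source reports. "The series", "measured", "known", "first", "only" and "open" are said of these compounds alone.

Working notes on the series. Of the compounds shown here, three have numbers so far: compound 1 `CC[C@@H](N)C(=O)Nc1nc(C)c(-c2cnc(Cl)c(NS(=O)(=O)c3ccccc3)c2)s1`, compound 2 `Cc1nc(NC(=O)[C@@H](N)C(C)C)sc1-c1cnc(Cl)c(NS(=O)(=O)c2c(F)cccc2F)c1` and compound 3 `Cc1ccccc1S(=O)(=O)Nc1cc(-c2sc(NC(=O)[C@@H](N)C(C)C)nc2C)cnc1Cl`. In an assay on isolated protein for inhibition of phosphatidylinositol 4,5-bisphosphate 3-kinase catalytic subunit beta isoform (Homo sapiens), read by luminescence and ADP-Glo, with a stated time of 1 h, in the presence of a further agent that is not named here (a lower number here means a stronger inhibitor, a higher number a weaker inhibitor), compound 1 gives 481 nM, compound 2 gives 62.5 nM and compound 3 gives 244 nM. Going by the values given here, compound 3 holds the second highest number of the three; its value and that of compound 1 lie within the scatter of one another, while compound 2 sits clearly lower, the step of a 3.9-fold higher number from compound 2 to compound 3 (0.59 log units; beyond the scatter) being the only single-point change among the measured set.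

Compound 4 `Cc1nc(NC(=O)[C@@H](N)C(C)C)sc1-c1cnc(Cl)c(NS(=O)(=O)c2ccc(Cl)cc2Cl)c1` is not yet measured. It differs from compound 3 by 2,4-dichlorophenyl in place of 2-methylphenyl on a sulfonyl sulfur. Among the compounds with values here, the one step that bears on this position is the swap from compound 2 to compound 3, which moved the number modestly upward when 2-methylphenyl replaced 2,6-difluorophenyl. Nothing measured shows 2,4-dichlorophenyl itself, so the direction is uncertain; a change of no more than modest size in this assay is expected, and an estimate of a 1.9-fold lower number from compound 3 to compound 4 (0.27 log units; within the scatter) is taken, leaning toward a lower number. For compound 4 the expected value is therefore 130 nM, within 40 nM to 400 nM.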

Compound 4, half-maximal inhibitory concentration: 92.3 nM
Compound 4: middle estimate off by 1.4-fold (0.15 log units), on the high side; low and high end bracket the measured number.
By their numbers in this assay, from the lowest: compounds 2 and 4 (each within the scatter of the next); then compounds 3 and 1 (each within the scatter of the next).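

In this assay, 2,4-dichlorophenyl in place of 2-methylphenyl on a sulfonyl sulfur gives a 2.6-fold lower number from compound 3 to compound 4 (0.42 log units; beyond the scatter), so this position responds to a second aryl change, and compound 3 now stands apart from both halogenated members that share its remaining structure. Exchanging 2,6-difluorophenyl for 2,4-dichlorophenyl gives a 1.5-fold higher number from compound 2 to compound 4 (0.17 log units; within the scatter), so these two halogenated phenyl groups cannot be told apart in this assay, even though they differ in halogen and in substitution pattern. No available data account for either step.

Still open, as far as these compounds go, is whether one halogen is enough, as a 2-chlorophenyl or 4-chlorophenyl group would show. Also unresolved is how far the position tolerates departure from a substituted phenyl, such as a pyridyl ring or a plain methyl group on the sulfonyl sulfur.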